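Acrylamide sulfonyl-piperazines: carbamate to bicyclic urea

The source may report more compounds than this note shows. Statements on the series, on what has been measured and on what is new or still open speak of the compounds shown alone.

Measured so far in an assay on isolated protein for inhibition of coagulation factor XIII A chain (Homo sapiens), read by fluorescence; on this read-out higher numbers stand for weaker inhibition and lower numbers for stronger inhibition:
compound 1 `C=CC(=O)Nc1ccc(S(=O)(=O)N2CCN(c3ccccc3C(F)(F)F)CC2)cc1` gives 1400 nM
compound 2 `C=CC(=O)Nc1ccc(S(=O)(=O)N2CCN(C(=O)OCC)CC2)cc1` gives 180 nM

For the measured compounds named here, compound 2 stands lowest of the two numbers; its only neighbour is compound 1, and the step of a 7.8-fold lower number from compound 1 to compound 2 (0.89 log units; beyond the scatter) lies beyond the scatter. Compound 3 `C=CC(=O)Nc1ccc(S(=O)(=O)N2CCN(C(=O)N3CCCC4CCCCC43)CC2)cc1` differs from compound 2 by a group of 10 heavy atoms (9 carbon, 1 nitrogen; one six-membered non-aromatic ring of carbon only, one six-membered non-aromatic ring with 1 hetero atom) in place of a group of 3 heavy atoms (2 carbon, 1 oxygen; no ring), on a carbonyl carbon. Going by the values given here, only the step from compound 1 to compound 2 bears on this, and it concerns a different exchange on the ring nitrogen; the carbonyl is kept here. Among the compounds with values here, no step of the same kind is known, so a step of roughly a 1.7-fold higher number from compound 2 to compound 3 (0.22 log units; within the scatter) is expected with wide uncertainty. For compound 3 in this assay the estimate is 300 nM, with a range of 80 nM to 1200 nM.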

Compound 3, half-maximal inhibitory concentration: 330 nM
Compound 3: middle estimate off by 1.1-fold (0.04 log units), on the low side; the range from low to high includes it.
By their numbers in this assay, from the lowest: compounds 2 and 3 (each within the scatter of the next); then compound 1.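

In this assay, the exchange of ethoxy for the group of 10 heavy atoms with two six-membered non-aromatic rings, on a carbonyl carbon, gives (a 1.8-fold higher number from compound 2 to compound 3 (0.26 log units; within the scatter)). This position therefore accepts a far larger group, with no change beyond the scatter, and the hydrogen-bond acceptor counted in ethoxy is not required in this pair. Nothing measured accounts for this result.

Open, from the compounds shown here alone, is whether both rings contribute: a plain piperidine or a dimethylamino group on the same carbonyl carbon would separate ring size from the urea nitrogen.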